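This account rests on a few compounds, and the source may have more. Where it says the series, first, only, none or still open, it means among the compounds named here.

Measured in a functional assay on the whole organism for positive allosteric modulation, with Mus musculus as the target; on this read-out lower numbers stand for an effect already at smaller amounts and higher numbers for an effect only at larger amounts of compound
compound 1 `CCC(=O)N(c1cccc(OC)c1)C1CCCC1N(C)C` gives 0.8 mg/kg
compound 2 `CCC(=O)N(c1cccc(F)c1)C1CCCC1N(C)C` gives 0.4 mg/kg
compound 3 `CCC(=O)N(c1c(F)c(F)c(F)c(F)c1F)C1CCCC1N(C)C` gives > 50 mg/kg
compound 4 `CCC(=O)N(c1cccc(C(F)(F)F)c1)C1CCCC1N(C)C` is not yet measured

Only two of these compounds give real numbers, and they sit close together. Among the measured compounds shown here, the gap between them is a 2.0-fold lower number from compound 1 to compound 2 (0.30 log units; within the scatter), so neither can be ranked ahead of the other, and compound 2 stands level with its one neighbour. Compound 3 gives > 50 mg/kg as a limit of the assay, not a number.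

The next step starts from compound 2 and puts trifluoromethyl in place of fluoro on an aromatic carbon. For the measured compounds named here, the one measured step that swaps a single group on an aromatic carbon is a 2.0-fold lower number from compound 1 to compound 2 (0.30 log units; within the scatter), and it stayed within the scatter. Compound 3 differs in more than one place, so it offers no step size to carry over, though it does argue for a wide upper range. The expected change is a 1.8-fold higher number from compound 2 to compound 4 (0.24 log units; within the scatter) and no shift beyond the scatter is expected. In this assay the estimated value for compound 4 is 0.7 mg/kg with an expected range from 0.2 mg/kg to 4 mg/kg.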

Compound 4, dose for half-maximal effect: 0.3 mg/kg
The estimate for compound 4 lay 2.3-fold (0.37 log units) above the measured number, within the range that was stated.
By their numbers in this assay, from the lowest: compounds 4, 2 and 1 (each within the scatter of the next, the first and the last beyond it). At a limit, above all of these: compound 3.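

Trifluoromethyl in place of fluoro, on an aromatic carbon meta to a large group, gives a 1.3-fold lower number from compound 2 to compound 4 (0.12 log units; within the scatter), so in this assay this position takes a group with more heavy atoms without a clear change in the number. Set against methoxy at the same position, trifluoromethyl gives a 2.7-fold lower number from compound 1 to compound 4 (0.43 log units; beyond the scatter), the only step shown that clears the scatter, and a modest one. No measurement shown here bears on the reason for these numbers.

From the compounds shown here alone, whether a group of another kind at this position, such as an amine or a carboxylic acid, would fit in with these numbers remains open. Going by these compounds, compound 3 gives > 50 mg/kg, a limit and not a number, and it differs from the others in more than one place, so which of its fluoro groups matter also stays open.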